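Methyl for methoxy on the benzoyl ring of compound 2

A few compounds are considered here, and "the series" means these few. Any claim that something is new, unique, unknown or untested is made for them only; others in the source may bear on it.

Measured so far:
- compound 1, `COC(=O)c1c(Nc2ccc(F)cc2)sc(C(=O)c2ccc(OC)cc2)c1C`: 25.6%
- compound 2, `COC(=O)c1c(Nc2ccc(Cl)cc2)sc(C(=O)c2ccc(OC)cc2)c1C`: "not active" (no number reported), no number given

In a functional assay, with a stated time of 150 min, tested at 35 ug/mL (on this read-out higher numbers stand for a stronger effect at the one concentration tested and lower numbers for a weaker effect), compound 1 gives 25.6%, a modest read-out at the single concentration tested. Compound 2 stands below that on the numbers shown: in this assay compound 2 is reported as "not active" (no number reported) and carries no number, so no step between compound 1 and compound 2 can be sized. Compound 3, `COC(=O)c1c(Nc2ccc(Cl)cc2)sc(C(=O)c2ccc(C)cc2)c1C`, keeps the core of compound 2 and differs in one place: methyl in place of methoxy on an aromatic carbon. Among the compounds with values here, no measured pair shows this change, so its size in this assay is unknown; the expectation is either no step beyond the scatter or a small one in either direction from the inactive level of compound 2. Compound 3 is therefore estimated at 10% in this assay, within 0% to 30%, with a fair chance that only "not active" is reported again.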

Compound 3, a percentage reported as activity, at one concentration (the size of the read-out at that concentration, not a potency): "not active" (no number reported)
No number was reported for compound 3; no gap can be computed for the estimate.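

Neither compound 2 nor compound 3 carries a number in this assay, so no new step can be read between them. From the compounds shown here alone, whether going from 4-methoxyphenyl to 4-methylphenyl changes the read-out in a compound with a measurable value remains open. No measured evidence bears on this result.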